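The source may hold more compounds than are shown below. What is called first, only, known or untested is meant among the compounds shown, and "the series" means these compounds.

In a physicochemical assay for lipophilicity, using the shake flask method, measured as octanol-water partition, at pH 7.4 (on this read-out lower numbers stand for lower lipophilicity and higher numbers for higher lipophilicity), compound 1 (`CC(=O)N[C@@H]1CCC[C@H](C(=O)Nc2cc(-c3cnc4n3CCCC4)c(Cl)cn2)C1`) gives 2.7 and lies within the scatter of both measured relatives: compound 2 (`CC(=O)N[C@@H]1CCC[C@H](C(=O)Nc2cc(-c3cnn4c3CCC4)c(Cl)cn2)C1`) gives 2.9 and compound 3 (`CC(=O)N[C@@H]1CCC[C@H](C(=O)Nc2cc(-c3cnn4c3COCC4)c(Cl)cn2)C1`) gives 2.4 on the same scale. Compound 4 (`CC(=O)N[C@@H]1CCC[C@H](C(=O)Nc2cc(-c3cnn4c3CN(C)CC4)c(Cl)cn2)C1`) departs from compound 1 in one place: a group of 10 heavy atoms (7 carbon, 3 nitrogen; one five-membered aromatic ring with 2 hetero atoms, one six-membered non-aromatic ring with 2 hetero atoms) in place of a group of 9 heavy atoms (7 carbon, 2 nitrogen; one five-membered aromatic ring with 2 hetero atoms, one six-membered non-aromatic ring with 1 hetero atom), on an aromatic carbon and ortho to a chloro group. The closest guide is compound 3, which also carries a six-membered non-aromatic ring with 2 hetero atoms, and that swap gave a number 0.30 log units lower from compound 1 to compound 3 (within the scatter) as its result. Shrinking the ring instead gave a number 0.20 log units higher from compound 1 to compound 2 (within the scatter) as a result, and only a number 0.50 log units lower from compound 2 to compound 3 (beyond the scatter) passes beyond the scatter, modestly. Among the measured compounds shown here, no measurement yet shows how the group entering compound 4 behaves itself. For compound 4 the expected change is a number 0.30 log units lower from compound 1 to compound 4 (within the scatter) and so nothing clearly beyond the scatter. For compound 4 the estimated value is 2.4 with an expected range from 2 to 2.8 on this scale.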

Compound 4, distribution coefficient: 2.1
Beside the measured number, compound 4's estimate is 0.30 log units above it; the measured number falls inside the stated range.
By their numbers in this assay, from the lowest: compounds 4, 3, 1 and 2 (each within the scatter of the next, the first and the last beyond it).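

Among the compounds shown here, compound 4 is the first compound with a six-membered non-aromatic ring with 2 hetero atoms to move clearly away from compound 1 in this assay, with a number 0.60 log units lower from compound 1 to compound 4 (beyond the scatter), whereas the oxygen-containing ring of compound 3 stayed within the scatter of compound 1. The two rings with 2 hetero atoms still cannot be told apart, given a number 0.30 log units lower from compound 3 to compound 4 (within the scatter), while the step from the five-membered non-aromatic ring is the widest in this set, at a number 0.80 log units lower from compound 2 to compound 4 (beyond the scatter). Nothing shown here explains why these numbers differ.

Left open is where a ring carrying an acetyl group or a carboxylic acid would fall on this scale. As far as these compounds go, it also remains unknown whether the step from compound 1 to compound 4 would be similar on a different core.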